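This account rests on a few compounds, and the source may have more. Where it says the series, first, only, none or still open, it means among the compounds named here.

In an assay on isolated protein with Bile acid receptor (Homo sapiens) as the target (a lower number here means that less compound is needed, a higher number that more compound is needed for the effect), compound 2, with the structure `COC/C=C/c1cccc(N(Cc2ccc(/C=C/C(=O)OC(C)(C)C)cc2)C(=O)C2CCCCC2)c1`, gives 243 nM. Among the numbers available it stands lowest. Compound 1, with the structure `COC(=O)/C=C/c1cccc(N(Cc2ccc(-c3cccc(OC)c3)cc2)C(=O)NC(C)C)c1`, gives 1370 nM in the same assay, a higher number that lies beyond the usual scatter of repeated measurements. Compound 3, with the structure `COC(=O)/C=C/c1cccc(N(Cc2cccc(Br)c2)C(=O)C2CCCCC2)c1`, is recorded only as a limit of the assay, > 1000 nM, meaning no exact number was obtained; this is the limit of > 1000 nM in this assay, at which 1 of the 3 values shown sits.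

Compound 4, with the structure `CC(C)(C)OC(=O)/C=C/c1ccc(CN(C(=O)C2CCCCC2)c2cccc(/C=C/C(=O)OC(C)(C)C)c2)cc1`, has not yet been measured. It differs from compound 2 in one place: tert-butoxycarbonyl in place of methoxymethyl on a double-bonded chain carbon bound to a double-bonded chain carbon. After the change, both chains hanging off the shared core carry the same tert-butoxycarbonyl-bearing double bond, whereas in compound 2 only the chain on the benzyl side does.

Among the compounds with values here, no pair of measured compounds differing in a single place is available, so the size of this step cannot be read directly from the data. The step from compound 2 to compound 4, a 1.5-fold lower number from compound 2 to compound 4 (0.18 log units; within the scatter), is expected to be modest, with a slight lean toward a lower number, but it may well fall within the scatter. The estimate for compound 4 in this assay is therefore 160 nM, with a likely range from 45 nM to 600 nM.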

Compound 4, half-maximal effective concentration: > 1000 nM
Compound 4: only a limit was reported (the forecaster's own chance of this, stated with the estimate: 10%); at least 6.2-fold (0.79 log units) between middle value and limit.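

Compound 4 is recorded in this assay only as a limit of the assay, not as an exact number: the limit of > 1000 nM in this assay, at which 2 of the 4 values shown sit. Swapping methoxymethyl for tert-butoxycarbonyl on a double-bonded chain carbon bound to a double-bonded chain carbon comes with an at least 4.1-fold higher number from compound 2 to compound 4 (0.61 log units; beyond the scatter). Within the data shown here, the earlier compounds offered no single-change comparison, so this is the first direct sign that the group at this place matters for the number in this assay, and that the 3-methoxyprop-1-en-1-yl chain of compound 2 cannot be exchanged for the 2-(tert-butoxycarbonyl)ethenyl chain without a clear loss.

On these data alone, since one side of this step is a limit, its full size stays unknown, and a single pair cannot show which feature of the entering group is responsible, whether its larger count of heavy atoms, its extra hydrogen-bond acceptor or something else. Also open, as far as these compounds go, is how the number would respond to other groups at this chain end, such as a carboxylic acid, an amine or a methyl ester, which could show whether anything here matches or improves on methoxymethyl.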